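Swapping an Amide Substituent on a Kinase Binder

The compounds below may be only part of what the source reports. "The series", "measured", "known", "first", "only" and "open" are said of these compounds alone.

Compound 1 `Cc1cccc(Oc2ccnc(N3CCC[C@H]3C(=O)NCc3cccnc3)n2)c1` belongs to a small set of three compounds whose numbers all lie level with one another in an assay on isolated protein for inhibition of MAP kinase-activated protein kinase 2 (Homo sapiens), read by HTRF, tested at 10 uM; a lower number here means less inhibition, a higher number more inhibition at the concentration tested (going by the name of the read-out). Compound 1 gives 0%, compound 2 `Cc1cccc(Nc2ncnc3c2CN(C(=O)c2ccc(N(C)C)c4ccccc24)CC3)c1` gives 0%, and compound 3 `COC[C@@H]1CCCN1C(=O)[C@@H]1CCCN1c1cc(Nc2cccc(OC)c2)nc(N)n1` gives 2%, so none of them shows meaningful inhibition. Compound 4 `COC(=O)C(CO)NC(=O)[C@@H]1CCCN1c1nccc(Oc2cccc(C)c2)n1` keeps the core of compound 1 and alters one group on the amide-type nitrogen: 2-hydroxy-1-(methoxycarbonyl)ethyl in place of (pyridin-3-yl)methyl on an amide-type nitrogen. Among the compounds with values here, no measured pair shows how such a change moves this assay, so the step is expected to stay inside the usual scatter, with no clear direction: a number 2 percentage points higher from compound 1 to compound 4 (within the scatter) is the estimated shift. Compound 4 is thus expected to give about 2%, between -8% and 12%.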

Compound 4, a percentage reported as inhibition, at one concentration (the size of the read-out at that concentration, not a potency): 1%
The estimate for compound 4 lay 1 percentage points above the measured number; low and high end bracket the measured number.
By their numbers in this assay, from the lowest: compounds 1, 2, 4 and 3 (each within the scatter of the next).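

In this assay, putting 2-hydroxy-1-(methoxycarbonyl)ethyl in place of (pyridin-3-yl)methyl on the amide-type nitrogen brings a number 1 percentage points higher from compound 1 to compound 4 (within the scatter) and leaves both compounds without meaningful inhibition. At this position, then, an open chain with no ring and a group carrying a six-membered aromatic ring read alike. Nothing available explains this result. As far as these compounds go, whether a carboxylic acid or a longer alkyl chain on this nitrogen would lift the number stays open. With both compounds so low, this pair cannot show whether the position matters for inhibition at all.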